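Fluoro removal on the aryl ring of a thiosemicarbazone series

The compounds below may be only part of what the source reports. "The series", "measured", "known", "first", "only" and "open" are said of these compounds alone.

Compound 1 `CC(=NNC(=S)Nc1cccc(F)c1)c1ccccn1` and compound 2 `CC(=NNC(=S)Nc1ccccc1)c1ccccn1` share a core and differ by hydrogen in place of fluoro on an aromatic carbon, a step of a 50-fold lower number from compound 1 to compound 2 (1.70 log units; beyond the scatter). In a functional assay on MCF7 cells (Homo sapiens) for cytotoxicity, read by MTT assay, with a stated time of 48 h (a higher number here means a weaker inhibitor, a lower number a stronger inhibitor), compound 1 gives 9 nM and compound 2 gives 0.18 nM. Compound 3 `C/C(=N\NC(=S)Nc1ccccc1F)c1ccccn1` gives 0.39 nM in this assay; the difference between the core of compound 3 and that of compound 1 is not broken down here. Compound 4 `C/C(=N\NC(=S)Nc1ccccc1)c1ccccn1` is unmeasured and differs from compound 3 by hydrogen in place of fluoro on an aromatic carbon, the same kind of change as that from compound 1 to compound 2, with the fluoro leaving from a carbon ortho to a large group rather than meta to it. Given that compound 2 gives 0.18 nM, the step from compound 3 to compound 4 is expected to be a 2.0-fold lower number from compound 3 to compound 4 (0.29 log units; within the scatter). Compound 4 is therefore estimated at 0.2 nM, between 0.05 nM and 0.8 nM.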

Compound 4, half-maximal inhibitory concentration: 0.18 nM
Compound 4: the middle estimate sits 1.1-fold (0.05 log units) above what was measured, and the stated range covers the measured number.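

On the core of compound 3, the change gives a 2.2-fold lower number from compound 3 to compound 4 (0.34 log units; beyond the scatter), so the direction carries over from the earlier pair but the size does not: the same change on two cores in this assay, a 50-fold lower number (1.70 log units; beyond the scatter) from compound 1 to compound 2 and a 2.2-fold lower number (0.34 log units; beyond the scatter) from compound 3 to compound 4, 23-fold (1.36 log units) apart, beyond the scatter of two such steps

The pair reading no change at the digits printed from compound 2 to compound 4 (within the scatter) gives no sign that the drawn double-bond configuration alters the number, although compound 2 does not establish which form was tested: the fact that one of compounds 2 and 4 is drawn with a defined configuration and the other without, at the place where they differ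

Two pairs do not show whether the gap between the steps follows the place of the fluoro on the ring or something else, and they set no rule for other cores.

Open, on these data alone, is how a chloro, a methoxy or an amine on the same aromatic ring would compare with hydrogen and fluoro. Also open, as far as these compounds go, is whether the fluoro place alone accounts for the difference between the two steps.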